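From a urea to a carbamate on a shared core

The source may report more compounds than this note shows. Statements on the series, on what has been measured and on what is new or still open speak of the compounds shown alone.

Compound 1 `CCOc1ccc(-c2cccc(NC(=O)N(C)C)c2)cc1` gives 70000 nM in an assay on COS-7 cells for inhibition of patatin-like phospholipase domain-containing protein 2 (Mus musculus); on this read-out lower numbers stand for stronger inhibition and higher numbers for weaker inhibition. Compound 2 `CN(C)C(=O)Nc1cccc(-c2ccc(N(C)C)cc2)c1` is reported in this assay only as a limit, < 5000 nM. Going by the values given here, the single measured step, an at least 14-fold lower number from compound 1 to compound 2 (1.14 log units; beyond the scatter), concerns a change on an aromatic carbon and ends at the limit of < 5000 nM in this assay, at which 1 of the 2 values shown sits. Compound 3 `CN(C)c1ccc(-c2cccc(NC(=O)Oc3ccccc3)c2)cc1` differs from compound 2 by phenoxy in place of dimethylamino on a carbonyl carbon. Among the compounds with values here, no measured step touches the carbonyl carbon, and the limit on compound 2 leaves its position open. Compound 3 is expected to give 3000 nM in this assay, with a range of 300 nM to 30000 nM. The expected step is a step that the limit leaves unreadable from compound 2 to compound 3.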

Compound 3, half-maximal inhibitory concentration: 73000 nM
Estimate against measurement, compound 3: 24-fold (1.39 log units) below; the whole stated range lies below it.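

At the carbonyl carbon, phenoxy in place of dimethylamino gives an at least 14-fold higher number from compound 2 to compound 3 (1.16 log units; beyond the scatter) in this assay, so the read-out responds to the group at this position as well as to the group on the aromatic carbon. The true size of this step stays unknown, since compound 2 is reported only as a limit: the limit of < 5000 nM in this assay, at which 1 of the 3 values shown sits.

The compounds shown leave open whether methoxy or a piperidine ring on the same carbonyl carbon would behave like dimethylamino or like phenoxy. Nor do they separate the part played by the entering oxygen from that of the entering ring.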